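Moving a methyl on the sulfonate aryl of a stilbene core

This account rests on a few compounds, and the source may have more. Where it says the series, first, only, none or still open, it means among the compounds named here.

Measured so far:
- compound 1, `COc1cc(/C=C/c2ccc(C3=C(c4ccc(O)cc4)C4CC(S(=O)(=O)Oc5ccccc5)C3O4)cc2)cc(OC)c1`: > 100000 nM
- compound 2, `Cc1ccccc1OS(=O)(=O)C1CC2OC1C(c1ccc(/C=C/c3cc(O)cc(O)c3)cc1)=C2c1ccc(O)cc1`: 55800 nM

In a functional assay on MCF7 cells (Homo sapiens) for antiproliferative activity, read by MTT assay, with a stated time of 72 h (on this read-out higher numbers stand for weaker inhibition and lower numbers for stronger inhibition), compound 1 reaches only the limit of the assay, > 100000 nM, and no number is given for it. Among the compounds with values here, compound 2 is the only compound with a numeric value here, 55800 nM. Within the data shown here, the one further value shown, that of compound 1, is a limit (the limit of > 100000 nM in this assay, at which 1 of the 2 values shown sits). Among the measured compounds shown here, no step between measured compounds is available to calibrate the change.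

Compound 3, `Cc1cccc(OS(=O)(=O)C2CC3OC2C(c2ccc(/C=C/c4cc(O)cc(O)c4)cc2)=C3c2ccc(O)cc2)c1`, has not yet been measured. It differs from compound 2 in one place (3-methylphenyl in place of 2-methylphenyl on an oxygen). With the same atoms joined differently, a step no larger than the usual scatter is expected in this assay, in no firm direction, so a 1.1-fold lower number from compound 2 to compound 3 (0.05 log units; within the scatter) is estimated to be small. Compound 3 is therefore expected to give about 50000 nM, within 20000 nM to 120000 nM.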

Compound 3, half-maximal inhibitory concentration: 16300 nM
For compound 3 the middle estimate is 3.1-fold (0.49 log units) above the measured one; the measured number lies below the stated range.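

In this assay, the place of the methyl on the sulfonate aryl is not neutral: 3-methylphenyl in place of 2-methylphenyl on the oxygen gives a 3.4-fold lower number from compound 2 to compound 3 (0.53 log units; beyond the scatter). Within the data shown here, this is the first step that can be read at this position, and it shows that a change joining the same atoms differently can reach beyond the scatter here, though only modestly. Compound 1 remains a limit and provides no step: the limit of > 100000 nM in this assay, at which 1 of the 3 values shown sits.

The compounds shown do not tell why the number moves with this shift, or whether the same step would hold with the other substituents on the shared core. Also open, from the compounds shown here alone, is what a carboxylic acid or an amine in place of the methyl would give.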